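Taking the chloro off compound 2

The source may hold more compounds than are shown below. What is called first, only, known or untested is meant among the compounds shown, and "the series" means these compounds.

Values in a functional assay on SW982 cells (Homo sapiens) for inhibition, read by MTT assay, with a stated time of 72 h (a lower number here means a stronger inhibitor, a higher number a weaker inhibitor), by compound
Compound 1 `COc1cc(OC)c(OC)cc1/C=C/C(=O)c1ccc(Cl)cc1` at 58500 nM
Compound 2 `COc1cc(OC)c(OC)cc1/C=C/C(=O)c1ccc(Cl)c([N+](=O)[O-])c1` at 20600 nM

Compound 2 holds the lower of the two numbers, which makes it the stronger inhibitor of this pair. Compound 3 `COc1cc(OC)c(OC)cc1/C=C/C(=O)c1cccc([N+](=O)[O-])c1` carries hydrogen in place of chloro on an aromatic carbon. Going by the values given here, no measured step removes a chloro. Among the compounds with values here, the only guide is the modest step of a 2.8-fold lower number from compound 1 to compound 2 (0.45 log units; beyond the scatter) for nitro in place of hydrogen on an aromatic carbon, which is a different change. A small rise in the number in this assay is therefore expected, perhaps none beyond the scatter. The expected change is a 1.5-fold higher number from compound 2 to compound 3 (0.16 log units; within the scatter) in this estimate. Compound 3 is estimated at 30000 nM (range 11000 nM to 80000 nM).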

Compound 3, half-maximal inhibitory concentration: 101000 nM
Beside the measured number, compound 3's estimate is 3.4-fold (0.53 log units) below it; the whole stated range lies below it.
By their numbers in this assay, from the lowest: compound 2; then compounds 1 and 3 (each within the scatter of the next).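

Hydrogen in place of chloro gives a 4.9-fold higher number from compound 2 to compound 3 (0.69 log units; beyond the scatter) in this assay and so marks the first measured change at this aromatic carbon itself. With a nitro group ortho to it, the chloro clearly contributes to the lower number, and losing that one heavy atom makes compound 3 a weaker inhibitor than compound 2. No measurement here offers an explanation for this step.

Going by these compounds, whether chloro matters equally without the nitro group remains open. So does whether a fluoro, methyl or amine group on the same carbon would preserve the stronger inhibition.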